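The source may hold more compounds than are shown below. What is called first, only, known or untested is meant among the compounds shown, and "the series" means these compounds.

In a functional assay on A-375 cells (Homo sapiens) for cytotoxicity, read by CCK-8 assay, with a stated time of 24 h (on this read-out higher numbers stand for weaker inhibition and lower numbers for stronger inhibition), compound 1 `COc1ccc(-c2nc(N)c(Oc3ccccc3OC)c(Cl)n2)cc1` gives > 80000 nM, which is a limit of the assay and not a number. Compound 2 `COc1ccccc1Oc1c(N)nc(-c2ccccc2F)nc1Cl` gives > 80000 nM, again only a limit. Compound 2 therefore stands at the limit of > 80000 nM in this assay, at which 2 of the 2 values shown sit, and no number fixes its place. Compound 3 `COc1ccccc1Oc1c(N)nc(-c2ccc(F)cc2)nc1Cl` keeps the shared core and carries 4-fluorophenyl in place of 2-fluorophenyl, on an aromatic carbon between two ring nitrogen atoms: 4-fluorophenyl in place of 2-fluorophenyl on an aromatic carbon. Among the measured compounds shown here, only one measured change touches that same place, a step that the two limits leave unreadable from compound 1 to compound 2. For the measured compounds named here, with no step of readable size to draw on, no direction can be expected in this assay, and another limit is the likeliest reading. The expected outcome is a number no higher from compound 2 to compound 3 (the limit leaves the size open), with neither direction favoured. Compound 3 is estimated at about 80000 nM, with an expected range of 30000 nM to 160000 nM.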

Compound 3, half-maximal inhibitory concentration: 28200 nM
Compound 3: middle estimate off by 2.8-fold (0.45 log units), on the high side; measured number outside the range, below it.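

In this assay, among the compounds shown here, 4-fluorophenyl in place of 2-fluorophenyl gives an at least 2.8-fold lower number from compound 2 to compound 3 (0.45 log units; beyond the scatter), the first readable step at this position on an aromatic carbon between two ring nitrogen atoms, and it shows that the place of the fluoro group on the phenyl ring matters here. Fluoro in place of methoxy gives an at least 2.8-fold lower number from compound 1 to compound 3 (0.45 log units; beyond the scatter), so the group carried on that ring also matters, while the step between the two limit compounds remains unreadable. The full size of both readable steps stays open, since each starts from a limit and not a number: the limit of > 80000 nM in this assay, at which 2 of the 3 values shown sit.

From the compounds shown here alone, whether 3-fluorophenyl, or a phenyl ring carrying chloro, a nitrile or a carboxylic acid, would lower the number further remains open. With a single number among these compounds, no trend across this position can be drawn.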